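This account rests on a few compounds, and the source may have more. Where it says the series, first, only, none or still open, it means among the compounds named here.

In a functional assay on U-87MG ATCC cells for antiproliferative activity against U-87 MG (Homo sapiens), read by MTT assay, with a stated time of 48 h, tested at 100 uM (a lower number here means a stronger effect, a higher number a weaker effect of the compound at the concentration tested), compound 3, `Cc1nc(-c2ccccc2)sc1C(=O)CSc1nc(-c2ccc(Cl)c(Cl)c2)c(C#N)c(=O)[nH]1`, gives 24.4%. That is the second highest of three numbers. Compound 2, `Cc1nc(-c2ccc(Cl)cc2)sc1C(=O)CSc1nc(-c2ccc(Cl)c(Cl)c2)c(C#N)c(=O)[nH]1`, is nearest to it with 36.5%, and compound 1, `COc1ccc(-c2nc(C)c(C(=O)CSc3nc(N)c(C#N)c(-c4ccc(Cl)cc4)n3)s2)cc1`, is furthest with 3.9%. The only single-place step among these three is a number 12.1 percentage points lower from compound 2 to compound 3 (beyond the scatter), a modest step at the aryl ring on the thiazole side of the shared core.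

Compound 4 is `COc1ccc(-c2nc(SCC(=O)c3sc(-c4ccccc4)nc3C)[nH]c(=O)c2C#N)cc1OC`. It differs from compound 3 in one place: 3,4-dimethoxyphenyl in place of 3,4-dichlorophenyl on an aromatic carbon. For the measured compounds named here, no measured pair changes this ring, so the step from compound 2 to compound 3 bears on it only as a sign that swapping a chloro for hydrogen on a different aryl ring moved the number modestly. Compound 1 carries a methoxyphenyl but differs in several places, so its value cannot be read as a step. On this basis compound 4 is expected to give 22%, within 8% to 40%, which amounts to an estimated step of a number 2.4 percentage points lower from compound 3 to compound 4 (within the scatter), about the scatter.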

Compound 4, a percentage reported as activity, at one concentration (the size of the read-out at that concentration, not a potency): 6.48%
The estimate for compound 4 lay 15.5 percentage points above the measured number, outside the stated range (below it).
By their numbers in this assay, from the lowest: compounds 1 and 4 (each within the scatter of the next); then compound 3; then compound 2.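

For the compounds shown here, replacing 3,4-dichlorophenyl with 3,4-dimethoxyphenyl on the aromatic carbon ortho to a cyano group gives a number 17.9 percentage points lower from compound 3 to compound 4 (beyond the scatter) in this assay, which shows that the number responds to a change at this position, a place that no earlier pair had touched. The change swaps two chlorine atoms for two oxygen-bearing methoxy groups and brings in 2 hydrogen-bond acceptors where the leaving group has 0, so several features change together and this one pair cannot separate them. Nothing measured here accounts for the step.

Still open, from the compounds shown here alone, is whether a plain phenyl ring, or one carrying a carboxylic acid or an amine, would follow the same direction at this position. Also open, going by these compounds, is whether this step would hold with a chloro on the other aryl ring.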